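Adding a Methoxy Where Removing One Weakened the Effect

The source may hold more compounds than are shown below. What is called first, only, known or untested is meant among the compounds shown, and "the series" means these compounds.

Compound 1 `COc1ccc(C(=O)/C=C/c2cc(-c3cc(OC)c(OC)c(OC)c3)n[nH]2)cc1OC` gives -82% in a functional assay on SN12C cells (Homo sapiens) for cytotoxicity, read by sulforhodamine B assay, with a stated time of 48 h, tested at 10 uM (on this read-out higher numbers stand for a weaker effect at the one concentration tested and lower numbers for a stronger effect), the lowest of the two numbers shown. Compound 2 `COc1ccc(C(=O)/C=C/c2cc(-c3cc(OC)c(OC)c(OC)c3)n[nH]2)cc1` gives -69% in this assay; the step of a number 13 percentage points higher from compound 1 to compound 2 (beyond the scatter) came from hydrogen in place of methoxy on an aromatic carbon. Compound 3 `COc1cc(C(=O)/C=C/c2cc(-c3cc(OC)c(OC)c(OC)c3)n[nH]2)cc(OC)c1OC` differs from compound 1 by methoxy in place of hydrogen on an aromatic carbon. Among the compounds with values here, the only measured step that bears on this change runs the opposite way, so compound 3 is expected to move modestly lower, if beyond the scatter at all, by a number 5 percentage points lower from compound 1 to compound 3 (within the scatter). Compound 3 is therefore estimated at -87%, within a range from -100% to -72%.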

Compound 3, a percentage reported as activity, at one concentration (the size of the read-out at that concentration, not a potency): -86%
The estimate for compound 3 lay 1 percentage points below the measured number; the range from low to high includes it.
By their numbers in this assay, from the lowest: compounds 3 and 1 (each within the scatter of the next); then compound 2.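

Placing a methoxy on this aromatic carbon, ortho to a methoxy group, gives a number 4 percentage points lower from compound 1 to compound 3 (within the scatter) in this assay and so does not separate the two compounds. The earlier loss of a methoxy gave a number 13 percentage points higher from compound 1 to compound 2 (beyond the scatter) and therefore does not extend into a gain at this position. Nothing given here accounts for this difference between the two changes.

On these data alone, it remains open whether a hydroxyl, an ethoxy or an amine on this carbon would also stay within the scatter of compound 1.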